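A few compounds are considered here, and "the series" means these few. Any claim that something is new, unique, unknown or untested is made for them only; others in the source may bear on it.

Measured so far in an ADME assay on a cell-free system (plasma, Rattus norvegicus); a higher number here means a larger unbound share of the compound, a lower number a smaller unbound share:
Compound 1 `CN(C)S(=O)(=O)c1ccc(F)c(C#Cc2cc(Cl)ccc2OCC(=O)O)c1`: 0.007
Compound 2 `Cc1ccc(S(=O)(=O)N(C)C(C)C)cc1C#Cc1cc(Cl)ccc1OCC(=O)O`: "not determined" (no result reported)

Compound 2 has no place on this scale, since no result was reported for it in this assay. Any step that starts from it therefore starts without a number.

One structural change leads onward to compound 3 `Cc1ccc(S(=O)(=O)NC(C)C)cc1C#Cc1cc(Cl)ccc1OCC(=O)O`: hydrogen in place of methyl on a sulfonamide nitrogen. This puts hydrogen in place of methyl on a sulfonamide nitrogen, so that isopropyl(methyl)sulfamoyl becomes isopropylsulfamoyl.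

For the measured compounds named here, no measured pair shows what this swap does, so its size can only be expected. The expectation here is a step in neither direction beyond the usual scatter of repeated measurements. Going by the values given here, the one number available as an anchor is that of compound 1, at 0.007, a very small unbound share. Compound 3 keeps much of that structure, so a similarly small share seems likely, though this rests on a single measured compound.

In this assay, the estimate for compound 3 is 0.007, with an expected range from 0.002 to 0.02.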

Compound 3, unbound fraction: 0.004
Compound 3: middle estimate off by 1.8-fold (0.24 log units), on the high side, and the stated range covers the measured number.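

For the compounds shown here, compound 2 has no number in this assay and so the change from compound 2 to compound 3 gives no step that can be read. Nothing available bears on the result for compound 3.

On these data alone, what hydrogen in place of methyl on the sulfonamide nitrogen does to the unbound share remains open.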